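Urea substituent series on the shared core: ethyl to propyl

The compounds below may be only part of what the source reports. "The series", "measured", "known", "first", "only" and "open" are said of these compounds alone.

Measured so far:
- compound 1, `CNC(=O)NCc1ccccc1-c1ccc(CN2C(=O)[C@H](NC(=O)C(C)(C)N)CCc3ccccc32)cc1`: 1 nM
- compound 2, `CCNC(=O)NCc1ccccc1-c1ccc(CN2C(=O)[C@H](NC(=O)C(C)(C)N)CCc3ccccc32)cc1`: 6 nM
- compound 3, `CC(C)(N)C(=O)N[C@@H]1CCc2ccccc2N(Cc2ccc(-c3ccccc3CNC(=O)NCCO)cc2)C1=O`: 2 nM

All three values come from a functional assay (Pituitary gland cell) with Rattus norvegicus as the target; on this read-out higher numbers stand for an effect only at larger amounts of compound and lower numbers for an effect already at smaller amounts. Compound 3 sits second highest of the three numbers; its nearest neighbour is compound 1, within the scatter of it, and compound 2 is farther off, beyond the scatter. The next compound, compound 4 `CCCNC(=O)NCc1ccccc1-c1ccc(CN2C(=O)[C@H](NC(=O)C(C)(C)N)CCc3ccccc32)cc1`, differs from compound 3 by methyl in place of hydroxy on a saturated chain carbon, two bonds along the chain from an amide-type nitrogen.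

Among the compounds with values here, two measured steps bear on this. The step of a 3.0-fold lower number from compound 2 to compound 3 (0.48 log units; beyond the scatter) is the reverse of the present change in kind: it put a hydroxy onto the chain two bonds from the amide-type nitrogen. The step of a 6.0-fold higher number from compound 1 to compound 2 (0.78 log units; beyond the scatter) shows what adding a methyl to the urea chain did. Within the data shown here, both point the same way for compound 4: removing the hydroxy should undo the modest gain seen in this assay for compound 3, and the extra methyl is, on the one precedent, more likely to raise the number than lower it. Compound 4 is therefore expected to read somewhat higher than compound 3, a step of about a 3.5-fold higher number from compound 3 to compound 4 (0.54 log units; beyond the scatter), beyond the scatter but modest. The estimate for compound 4 in this assay is 7 nM, with a range of 2.5 nM to 20 nM.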

Compound 4, concentration for half-maximal effect: 144 nM
Compound 4: middle estimate off by 21-fold (1.31 log units), on the low side, and the stated range ends below it.
By their numbers in this assay, from the lowest: compounds 1 and 3 (each within the scatter of the next); then compound 2; then compound 4.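

In this assay the urea position does not respond evenly to chain growth: adding a methyl to the ethyl chain gives a 24-fold higher number from compound 2 to compound 4 (1.38 log units; beyond the scatter) and is a much larger step than the earlier methyl addition, a 6.0-fold higher number from compound 1 to compound 2 (0.78 log units; beyond the scatter), while the full change from the methyl urea to the propyl urea gives a 140-fold higher number from compound 1 to compound 4 (2.16 log units; beyond the scatter) in the same direction. The change from hydroxy to methyl at the chain end exchanges one heavy atom for one heavy atom, yet gives a 72-fold higher number from compound 3 to compound 4 (1.86 log units; beyond the scatter); among the compounds with a chain of this length, the outcome therefore depends on the end group, with the 2-hydroxyethyl urea of compound 3 staying within the scatter of compound 1 and the propyl urea of compound 4 well away from it. The data at hand offer no measurement that accounts for the size of these steps.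

From the compounds shown here alone, whether the rise continues or levels off with a longer chain such as butyl remains open. Also open, going by these compounds, is whether a 3-hydroxypropyl chain, or a terminal amine or carboxylic acid on the chain, would bring the number back towards that of compound 3.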